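The source may report more compounds than this note shows. Statements on the series, on what has been measured and on what is new or still open speak of the compounds shown alone.

Working notes on the series.

Two compounds have a value in a functional assay on MKN-45 cells (Homo sapiens) for cytotoxicity, read by MTT assay, with a stated time of 72 h; a lower number here means a stronger inhibitor, a higher number a weaker inhibitor. Compound 1 `CN(C)CCn1cnnc1-c1cc(Oc2ccc(NC(=O)N/N=C/c3c[nH]c4ccccc34)cc2F)ccn1` gives 790 nM in this assay. Compound 2 `CN(C)CCn1cnnc1-c1cc(Oc2ccc(NC(=O)N/N=C/c3cc(C(C)(C)C)cc(C(C)(C)C)c3O)cc2F)ccn1` gives 3300 nM in this assay, a higher number than compound 1, and the gap between the two is beyond the scatter; compound 1 holds the lowest number of the pair.

Compound 3 `COc1ccc(/C=N/NC(=O)Nc2ccc(Oc3ccnc(-c4nncn4CCN(C)C)c3)c(F)c2)c(OC)c1` is not yet measured. It differs from compound 1 in one place: 2,4-dimethoxyphenyl in place of 1H-indol-3-yl on a carbon with a double bond to nitrogen. The shared core is kept; only the aromatic group on the carbon with a double bond to nitrogen changes. Among the measured compounds shown here, no step between measured compounds covers this change, and the only other substitution at that carbon, seen in compound 2, is of a different kind, so it serves as a loose guide at most.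

The expectation for compound 3 is a weaker number than compound 1, a modest step of a 2.3-fold higher number from compound 1 to compound 3 (0.36 log units; beyond the scatter), since the one measured replacement of the indolyl group, compound 2 at 3300 nM, gave a higher number. Compound 3 is therefore estimated at 1800 nM in this assay, with a range from 700 nM to 4500 nM.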

Compound 3, half-maximal inhibitory concentration: 1680 nM
Compound 3: middle estimate off by 1.1-fold (0.03 log units), on the high side, within the range that was stated.
By their numbers in this assay, from the lowest: compound 1; then compounds 3 and 2 (each within the scatter of the next).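

In this assay, among the compounds shown here, the replacement of 1H-indol-3-yl by 2,4-dimethoxyphenyl on the carbon with a double bond to nitrogen gives a 2.1-fold higher number from compound 1 to compound 3 (0.33 log units; beyond the scatter) and this is the first step read directly at this position. It shows that the indolyl group is not required for a value in this range: compound 3 still reaches 1680 nM with a single carbon-only aromatic ring, no hydrogen-bond donor in the entering group and hydrogen-bond acceptors in their place, although the number is higher than that of compound 1. No measurement on hand accounts for the size of this step.

The compounds shown do not separate the loss of the indole ring and its hydrogen-bond donor from the arrival of the two methoxy groups, since all of these changes fall within the one step. Going by these compounds, how an unsubstituted phenyl, a phenyl with a single methoxy group at either of these places, or a pyridinyl ring would stand on this carbon remains open, and so does whether a hydroxyl group in place of a methoxy group would move the number.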